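Removing the Sulfur from a Hydroxamic Acid Side Chain

A few compounds are considered here, and "the series" means these few. Any claim that something is new, unique, unknown or untested is made for them only; others in the source may bear on it.

Of the compounds shown here, three sharing one core have been measured in a physicochemical assay for solubility; a higher number here means a more soluble compound, a lower number a less soluble compound. Compound 1, `COCCNC(=O)C[C@H](NC(=O)c1ccc(C#Cc2ccccc2)cc1)C(=O)NO`, gives 78000 nM. Compound 2, `CSC[C@H](NC(=O)c1ccc(C#Cc2ccccc2)cc1)C(=O)NO`, gives 2000 nM, and compound 3, `CS(=O)(=O)C[C@H](NC(=O)c1ccc(C#Cc2ccccc2)cc1)C(=O)NO`, gives 2000 nM. Compound 2 therefore stands level with compound 3 at the digits shown, the two together being the lowest of the three numbers, while its furthest neighbour is compound 1: a 39-fold lower number from compound 1 to compound 2 (1.59 log units; beyond the scatter). The matching step a 39-fold lower number from compound 1 to compound 3 (1.59 log units; beyond the scatter) is of the same size, and the step of no change at the digits printed from compound 2 to compound 3 (within the scatter) shows that swapping methylsulfanyl for methylsulfonyl made no difference beyond the scatter.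

Compound 4, `CC(C)C(NC(=O)c1ccc(C#Cc2ccccc2)cc1)C(=O)NO`, has not yet been measured. It differs from compound 2 as follows: a group of 8 heavy atoms (5 carbon, 1 nitrogen, 2 oxygen; no ring) in place of a group of 8 heavy atoms (4 carbon, 1 nitrogen, 2 oxygen, 1 sulfur; no ring), on an amide-type nitrogen. Within the data shown here, no measured step removes the sulfur-bearing group entirely, so the nearest guide is the step from compound 2 to compound 3, in which changing the sulfur group left this assay unchanged. A step of no more than the usual scatter is therefore expected from compound 2 to compound 4, that is a 1.1-fold lower number from compound 2 to compound 4 (0.05 log units; within the scatter), with the uncertainty leaning to a somewhat lower number. Compound 4 is estimated at 1800 nM, within a range from 600 nM to 5500 nM.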

Compound 4, solubility: 7000 nM
The estimate for compound 4 lay 3.9-fold (0.59 log units) below the measured number; measured number outside the range, above it.
By their numbers in this assay, from the lowest: compounds 2 and 3 (each within the scatter of the next); then compound 4; then compound 1.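

The sulfur-bearing groups of compound 2 and compound 3 gave no separation, but this position is not indifferent to every change: replacing the methylsulfanyl-bearing group with 1-(hydroxycarbamoyl)-2-methylpropyl, which contains no sulfur, gives a 3.5-fold higher number from compound 2 to compound 4 (0.54 log units; beyond the scatter) in this assay. The rise is modest beside the gap to the (2-methoxyethyl)carbamoyl compound, since compound 4 at 7000 nM remains under compound 1 at 78000 nM, so a group without sulfur on the amide-type nitrogen can lift the number without reaching the top of this small set. No supporting measurement accompanies these numbers to explain the step.

The compounds shown leave open how much of the remaining gap to compound 1 could be closed by other groups here, such as a chain ending in an amine or a carboxylic acid, or a longer hydrocarbon chain. They also do not separate the loss of sulfur from the other counted differences between the two groups, including the 1 defined stereocentre printed only for the group that leaves.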